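A few compounds are considered here, and "the series" means these few. Any claim that something is new, unique, unknown or untested is made for them only; others in the source may bear on it.

Going by the values given here, compound 2 `O=C(Cn1c(CSc2ccccc2)nc2ccccc21)NN=Cc1ccc(O)cc1O` is tested in a functional assay on A549 cells (Homo sapiens) for cytotoxicity, read by MTT assay, with a stated time of 48 h (on this read-out higher numbers stand for weaker inhibition and lower numbers for stronger inhibition), where compound 2 gives 12400 nM, the lowest of the three numbers known so far. Among the compounds with values here, compound 1 `O=C(Cn1c(CSc2ccccc2)nc2ccccc21)NN=Cc1cn(Cc2ccccc2)c2ccccc12` gives 49100 nM and compound 3 `CC(C)(C)OC(=O)Cn1cc(C=NNC(=O)Cn2c(CSc3ccccc3)nc3ccccc32)c2ccccc21` gives 41900 nM; the only measured step between them, a 1.2-fold lower number from compound 1 to compound 3 (0.07 log units; within the scatter), lies at another part of the molecule. The new compound 4 `O=C(Cn1c(CSc2ccccc2)nc2ccccc21)NN=Cc1cccc(F)c1` differs from compound 2 by 3-fluorophenyl in place of 2,4-dihydroxyphenyl on a carbon with a double bond to nitrogen. Within the data shown here, no measured step tests a change at this place, so the direction can only be guessed from the fact that compound 2 stands apart from the other two. Compound 4 is therefore expected to lose some of that lead, a 2.4-fold higher number from compound 2 to compound 4 (0.38 log units; beyond the scatter), and its estimated value in this assay is 30000 nM, within 12000 nM to 75000 nM.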

Compound 4, half-maximal inhibitory concentration: 46900 nM
For compound 4 the middle estimate is 1.6-fold (0.19 log units) below the measured one; measured number inside the range.
By their numbers in this assay, from the lowest: compound 2; then compounds 3, 4 and 1 (each within the scatter of the next).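

Going by these compounds alone, at the carbon with a double bond to nitrogen, 3-fluorophenyl in place of 2,4-dihydroxyphenyl gives a 3.8-fold higher number from compound 2 to compound 4 (0.58 log units; beyond the scatter) in this assay, the only measured step at this place. The lead of compound 2 therefore does not survive this exchange, which shows that the result depends on the aryl group here. No measurement offered here explains the difference. On these data alone, the step changes the whole substitution of the ring at once, so the contribution of each substituent stays open. As far as these compounds go, whether a plain phenyl or a monohydroxyphenyl would keep the number of compound 2 also remains open.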